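Aryl swaps on a shared core: cytotoxicity working notes

The source may hold more compounds than are shown below. What is called first, only, known or untested is meant among the compounds shown, and "the series" means these compounds.

Measured so far in an ADME assay on Vero cells (Chlorocebus sabaeus) for cytotoxicity, read by neutral red uptake, tested at 12.3 ug/mL; a lower number here means a stronger effect, a higher number a weaker effect of the compound at the concentration tested:
compound 1 `O=C1CSC(c2cccc(O)c2)N1CCN1CCCCC1`: 100%
compound 2 `Cc1ccc(C2SCC(=O)N2CCN2CCCCC2)cc1`: 100%
compound 3 `O=C1CSC(c2ccc(F)cc2)N1CCN1CCCCC1`: 100%

Compound 3 sits level with compounds 1 and 2 in this assay. The step of no change at the digits printed from compound 1 to compound 3 (within the scatter) and the step of no change at the digits printed from compound 2 to compound 3 (within the scatter) both stay within the scatter, as does the step of no change at the digits printed from compound 1 to compound 2 (within the scatter). Every change of the aryl group on the saturated ring carbon seen so far has therefore left this read-out unmoved.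

Compound 4 `O=C1CSC(c2ccccc2Cl)N1CCN1CCCCC1` is the next member, not yet measured in this assay. It differs from compound 3 as follows: 2-chlorophenyl in place of 4-fluorophenyl on a saturated ring carbon. The three measured steps all bear on this change, since each of them also exchanges one aryl group for another at the same saturated ring carbon, and none of them moved this assay beyond the scatter. On that basis no step beyond the scatter is expected from compound 3 to compound 4, in either direction; the expected step is no change at the digits printed from compound 3 to compound 4 (within the scatter). Compound 4 is estimated to give 100% in this assay, with an expected range from 88% to 100%.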

Compound 4, a percentage reported as activity, at one concentration (the size of the read-out at that concentration, not a potency): 100%
The estimate for compound 4 equals the measured number at the digits printed; measured number inside the range.
By their numbers in this assay, from the lowest: compounds 1, 2, 3 and 4 (each within the scatter of the next).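

In this assay the 2-chlorophenyl group extends the tested aryl groups to a chlorine-bearing ring, and the step reads no change at the digits printed from compound 3 to compound 4 (within the scatter) for the exchange of 4-fluorophenyl on the saturated ring carbon. The comparisons with the other two aryl groups read no change at the digits printed from compound 2 to compound 4 (within the scatter) and no change at the digits printed from compound 1 to compound 4 (within the scatter), so 3-hydroxyphenyl, 4-methylphenyl, 4-fluorophenyl and 2-chlorophenyl are all indistinguishable at this position in this read-out. No measurement at hand offers an explanation for this flat result.

As far as these compounds go, whether a phenyl group carrying an amine or a carboxylic acid would move this read-out remains open, as does a longer alkyl chain in place of the aryl group. The compounds shown also leave open any change elsewhere on the shared core, since all four differ only in this aryl group.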